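Compound 4: a smaller group on the carbonyl carbon

This account rests on a few compounds, and the source may have more. Where it says the series, first, only, none or still open, it means among the compounds named here.

Compound 1 `O=C(Nc1cccc(-n2cc(-c3ccncc3)c(-c3cc(O)cc(Cl)c3)n2)c1)Nc1ccc(Cl)c(C(F)(F)F)c1` gives -16.8% in a functional assay on M14 cells (Homo sapiens) for inhibition, read by sulforhodamine B assay, with a stated time of 48 h, tested at 10 uM; a higher number here means a weaker effect of the compound at the concentration tested, a lower number a stronger effect.
Compound 2 `COc1cc(Cl)cc(-c2nn(-c3cccc(NC(=O)Nc4ccc(Cl)c(C(F)(F)F)c4)c3)cc2-c2ccncc2)c1` gives 3.99% in this assay.
Compound 3 `COc1cc(Cl)cc(-c2nn(-c3cccc(NC(=O)Nc4cc(C(F)(F)F)cc(C(F)(F)F)c4)c3)cc2-c2ccncc2)c1` gives 1.22% in this assay.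

Compound 2 stands highest of the three numbers. Compound 3 lies nearest, with a reading within the scatter of compound 2, so the two are not distinguished. Compound 1 lies furthest: the step of a number 20.8 percentage points higher from compound 1 to compound 2 (beyond the scatter) is beyond the scatter and modest in size.

The unmeasured compound 4 `COc1cc(Cl)cc(-c2nn(-c3cccc(NC(=O)c4cccc(C(F)(F)F)c4)c3)cc2-c2ccncc2)c1` differs from compound 2 in one place: 3-(trifluoromethyl)phenyl in place of (4-chloro-3-(trifluoromethyl)phenyl)amino on a carbonyl carbon. Among the measured compounds shown here, no measured step touches this carbonyl carbon. For the measured compounds named here, the only measured step, a number 20.8 percentage points higher from compound 1 to compound 2 (beyond the scatter), concerns the methyl on an oxygen and does not bear on this change; compounds 2 and 3 differ in the group on the amide-type nitrogen and read within the scatter of each other. With nothing to anchor it, the step is expected to be small, a number 6 percentage points higher from compound 2 to compound 4 (within the scatter), perhaps not beyond the scatter. Compound 4 is therefore estimated at 10% in this assay, within a range from -12% to 40%.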

Compound 4, a percentage reported as activity, at one concentration (the size of the read-out at that concentration, not a potency): 56.3%
Beside the measured number, compound 4's estimate is 46.3 percentage points below it; measured number above the stated range.
By their numbers in this assay, from the lowest: compound 1; then compounds 3 and 2 (each within the scatter of the next); then compound 4.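

In this assay, the carbonyl carbon proves a sensitive place, with a number 52.3 percentage points higher from compound 2 to compound 4 (beyond the scatter) marking a much weaker effect at the concentration tested. Compounds 2 and 3, which differ in the substituents on the outer aromatic ring, read within the scatter of each other, so they gave no sign of this sensitivity. The change removes the amino nitrogen, with its hydrogen-bond donor, and the chlorine together, and nothing available explains the step.

The compounds shown leave open whether the nitrogen or the chlorine accounts for the step. A (3-(trifluoromethyl)phenyl)amino group on this carbonyl carbon would separate the two, and a benzyl group would test a carbon in place of that nitrogen.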